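This account rests on a few compounds, and the source may have more. Where it says the series, first, only, none or still open, it means among the compounds named here.

Four compounds built on one shared core were examined for how much is needed to produce an effect in a living mouse. Compound 1 `COc1cc2c(cc1OC)C(c1ccc(Br)cc1)=NNC(=O)C2` carries a bromo group on its outer ring and has a carbonyl in the core. Compound 2 `COc1cc2c(cc1OC)C(c1ccc(Br)cc1)=NN(C)C(=S)C2` keeps that bromo group but differs from compound 1 in the core itself; how the two cores differ is not broken down here. Compound 3 `COc1cc2c(cc1OC)C(c1ccccc1)=NNC(=O)C2` has the core of compound 1 with the bromo group gone, and compound 4 `COc1cc2c(cc1OC)C(c1ccccc1)=NN(C)C(=S)C2` has the core of compound 2 with the bromo group gone.

In a functional assay on the whole organism with Mus musculus as the target (on this read-out higher numbers stand for an effect only at larger amounts of compound and lower numbers for an effect already at smaller amounts), compound 1 gives 82.5 umol/kg. In this assay compound 2 gives 60.4 umol/kg, a number that lies within the usual scatter of that for compound 1. In this assay compound 3 gives 31.8 umol/kg.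

The change from compound 1 to compound 3 is hydrogen in place of bromo on an aromatic carbon. It made a 2.6-fold lower number from compound 1 to compound 3 (0.41 log units; beyond the scatter). The change from compound 2 to compound 4 is hydrogen in place of bromo on an aromatic carbon, the same change at the same place, made on the other core. For the measured compounds named here, no other pair shows it, so its size here rests on that one step alone.

Because the step of a 2.6-fold lower number from compound 1 to compound 3 (0.41 log units; beyond the scatter) was modest but beyond the scatter, a step of about the same size is expected from compound 2 to compound 4, namely a 2.4-fold lower number from compound 2 to compound 4 (0.38 log units; beyond the scatter). For compound 4 in this assay the expected value is 25 umol/kg, estimated to fall between 12 umol/kg and 50 umol/kg.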

Compound 4, dose for half-maximal effect: 24.7 umol/kg
Compound 4: the middle estimate sits 1.0-fold (0.01 log units) above what was measured, within the range that was stated.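

On the core of compound 2, swapping bromo for hydrogen, which turns 4-bromophenyl into phenyl, gives in this assay a 2.4-fold lower number from compound 2 to compound 4 (0.39 log units; beyond the scatter). Set beside the earlier step on the core of compound 1, the change carries over from one core to the other with much the same size, and the two steps cannot be told apart: the same change on two cores in this assay, a 2.6-fold lower number (0.41 log units; beyond the scatter) from compound 1 to compound 3 and a 2.4-fold lower number (0.39 log units; beyond the scatter) from compound 2 to compound 4, 1.1-fold (0.03 log units) apart, within the scatter of two such steps. This supports treating the loss of bromo as a roughly constant step across these two cores, but it rests on just two pairs of compounds, so it is no rule for the whole series, and a dose measured in a living mouse does not reveal what lies behind the shift.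

The compounds shown have only bromo or hydrogen at this spot on the outer ring, so it remains open whether a chloro group, a methoxy group, an amine or a carboxylic acid there would follow the same trend, or whether the step would hold on a third core. The two cores also differ from each other in more than one place, which leaves the contribution of each separate difference in the core unresolved.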